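Anilide variation on a uridine-cytidine kinase 2 series

The source may report more compounds than this note shows. Statements on the series, on what has been measured and on what is new or still open speak of the compounds shown alone.

Measured so far:
- compound 1 `O=C(CSCn1[nH]nc2c(=O)nc(Cc3ccc(F)cc3)nc1-2)Nc1ccc(F)cc1`: 19.3%
- compound 2 `COc1cccc(NC(=O)CSCn2[nH]nc3c(=O)nc(Cc4ccc(F)cc4)nc2-3)c1`: "not active" (no number reported)
- compound 3 `O=C(CSc1nc2n(-c3ccc(F)cc3)[nH]cc-2c(=O)n1)Nc1ccc(Br)cc1`: 31.3%

The read-out throughout is an assay on K562 cells for inhibition of uridine-cytidine kinase 2 (Homo sapiens), with a stated time of 24 h, tested at 50 uM; a lower number here means less inhibition, a higher number more inhibition at the concentration tested (going by the name of the read-out). Compound 1 gives 19.3% in this assay, compound 3 gives 31.3%, and compound 2 is reported only as "not active" (no number reported), with no number attached. Compound 2 therefore has no position on the scale; it can only be placed as showing no measurable inhibition at the tested concentration, beneath the readings of compound 1 and compound 3.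

The next compound in the set is compound 4 `Cc1ccccc1NC(=O)CSCn1[nH]nc2c(=O)nc(Cc3ccc(F)cc3)nc1-2`. It differs from compound 2 in one place: 2-methylphenyl in place of 3-methoxyphenyl on an amide-type nitrogen

Going by the values given here, no measured pair in the set differs at this position, so the size of the step from compound 2 to compound 4 in this assay is unknown. The two neighbours that carry a different anilide, compound 1 and compound 3, both sit at modest inhibition, so a small gain is expected at most, and a result within the scatter of compound 2 is at least as likely as one beyond it.

For compound 4 in this assay the expected inhibition is 15%, with a range from 0% to 32%, the low end reflecting a fair chance that it too is reported only as not active.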

Compound 4, a percentage reported as inhibition, at one concentration (the size of the read-out at that concentration, not a potency): 26.3%
Compound 4: the middle estimate sits 11.3 percentage points below what was measured; measured number inside the range.
By their numbers in this assay, from the lowest: compounds 1, 4 and 3 (each within the scatter of the next, the first and the last beyond it).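

In this assay the anilide position now has a numeric reading for 2-methylphenyl: compound 4 gives 26.3% while compound 2, with 3-methoxyphenyl on the same amide-type nitrogen, is reported only as not active, so the change from compound 2 to compound 4 cannot be read as a step of any size. The step of a number 7 percentage points higher from compound 1 to compound 4 (within the scatter) comes with 2-methylphenyl in place of 4-fluorophenyl, so these two anilides read alike and, among the three compounds sharing this core, only compound 2 stands apart. No measurement shown here accounts for the difference between the anilides.

The change from 3-methoxyphenyl to 2-methylphenyl swaps both the group and its place on the ring, so the shown compounds cannot separate the two; 3-methylphenyl and 2-methoxyphenyl anilides would. From the compounds shown here alone, it also remains open whether a phenyl ring carrying an amine or a carboxylic acid, or a longer chain on the amide-type nitrogen in place of the aryl group, would read differently from compound 1 and compound 4.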